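The source may report more compounds than this note shows. Statements on the series, on what has been measured and on what is new or still open speak of the compounds shown alone.

In an ADME assay on WI-38 cells (Homo sapiens) for cytotoxicity, read by MTT assay, with a stated time of 72 h (on this read-out lower numbers stand for stronger inhibition and higher numbers for weaker inhibition), compound 1 `CN(C)CCn1cnnc1-c1cc(Oc2ccc(NC(=O)N/N=C/c3ccc(O)c(Br)c3)cc2F)ccn1` gives 5560 nM, compound 2 `Cc1cc(/C=N/NC(=O)Nc2ccc(Oc3ccnc(-c4nncn4CCN(C)C)c3)c(F)c2)cc(C)c1O` gives 3610 nM, and compound 3 `COc1cc(/C=N/NC(=O)Nc2ccc(Oc3ccnc(-c4nncn4CCN(C)C)c3)c(F)c2)ccc1O` gives 5320 nM. On these numbers compound 3 stands second highest of the three, and all three lie within the scatter of one another: a 1.5-fold lower number from compound 1 to compound 2 (0.19 log units; within the scatter), a 1.0-fold lower number from compound 1 to compound 3 (0.02 log units; within the scatter) and a 1.5-fold higher number from compound 2 to compound 3 (0.17 log units; within the scatter). Compound 4 `CN(C)CCn1cnnc1-c1cc(Oc2ccc(NC(=O)N/N=C/c3ccc(Cl)cc3Cl)cc2F)ccn1` has not yet been measured. It differs from compound 3 only at the aromatic ring carried on the carbon with a double bond to nitrogen (2,4-dichlorophenyl in place of 4-hydroxy-3-methoxyphenyl on a carbon with a double bond to nitrogen). The two measured steps that change the same ring, from compound 1 to compound 2 and from compound 2 to compound 3, both stayed within the scatter, so the ring at this position has so far moved the read-out little. The change to compound 4 is larger in kind than those steps, since the hydroxy group leaves with the ring, yet nothing measured here points in a direction, and no step beyond the scatter is expected: a 1.1-fold lower number from compound 3 to compound 4 (0.03 log units; within the scatter). Compound 4 is therefore estimated at 5000 nM, with a range from 2000 nM to 13000 nM.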

Compound 4, half-maximal inhibitory concentration: 4760 nM
Compound 4: middle estimate off by 1.1-fold (0.02 log units), on the high side; the range from low to high includes it.
By their numbers in this assay, from the lowest: compounds 2, 4, 3 and 1 (each within the scatter of the next).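

In this assay, compounds 1, 2 and 3 all carry a hydroxy group on the ring at this position, while the 2,4-dichlorophenyl ring of compound 4 has none, and the step stays within the scatter against each of them (a 1.1-fold lower number from compound 3 to compound 4 (0.05 log units; within the scatter); a 1.3-fold higher number from compound 2 to compound 4 (0.12 log units; within the scatter); a 1.2-fold lower number from compound 1 to compound 4 (0.07 log units; within the scatter)). In these four compounds, then, the read-out does not depend on that hydroxy group, and replacing it along with the ring's other groups by two chlorines leaves the cytotoxicity number unmoved. Nothing given here explains this lack of response.

Going by these compounds, all four rings are aromatic rings of carbon only, so a saturated cyclohexyl ring at this position remains untested here. So does an amine or a carboxylic acid on the ring.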